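One Stereocentre Flipped: What to Expect for Compound 3

This account rests on a few compounds, and the source may have more. Where it says the series, first, only, none or still open, it means among the compounds named here.

Measured so far:
compound 1, `CN1CCC(N2CCN(C(=O)C3CCN(C(=O)c4nc5ccccc5n4Cc4ccccc4)CC3)CC2)CC1`: 4020 nM
compound 2, `CN1CCC(N2CCN(C(=O)[C@H]3CCCN3C(=O)c3nc4ccccc4n3Cc3ccccc3)CC2)CC1`: 3220 nM

Of the compounds shown here, two have been tested in a functional assay on CHO cells for antagonist activity at B1 bradykinin receptor (Macaca fascicularis), read by FLIPR and calcium flux; on this read-out higher numbers stand for weaker inhibition and lower numbers for stronger inhibition. Compound 1 gives 4020 nM in this assay, and compound 2 gives 3220 nM. Compound 2 has the lower of the two numbers, but the gap to compound 1 lies within the scatter, so the two cannot be told apart on these data; both sit at the weak end of the scale.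

Compound 3, `CN1CCC(N2CCN(C(=O)[C@@H]3CCCN3C(=O)c3nc4ccccc4n3Cc3ccccc3)CC2)CC1`, is not yet measured. (the two compounds have the same atoms and bonds and differ only in configuration as drawn: 1 of 1 stereo elements differ; a stereocentre at a saturated ring carbon is drawn R in compound 2 and S in compound 3). For the measured compounds named here, no measured pair differs only in configuration, so nothing here shows how large such a change is in this assay. Inverting a single ring carbon can leave the number where it is or move it in either direction, and with nothing to point the way, the expectation is placed close to compound 2 with a wide range. Compound 3 is expected to give 3000 nM in this assay, somewhere between 700 nM and 13000 nM. The estimated step of a 1.1-fold lower number from compound 2 to compound 3 (0.03 log units; within the scatter) is expected to stay within the scatter, while the range allows for a real shift either way.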

Compound 3, half-maximal inhibitory concentration: 884 nM
Beside the measured number, compound 3's estimate is 3.4-fold (0.53 log units) above it; measured number inside the range.
By their numbers in this assay, from the lowest: compound 3; then compounds 2 and 1 (each within the scatter of the next).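

In this assay, for the compounds shown here, turning a single saturated ring carbon from R to S gives a 3.6-fold lower number from compound 2 to compound 3 (0.56 log units; beyond the scatter), the first step in this small set that lies beyond the scatter. Going by these compounds alone, this shows that the configuration at this one ring carbon matters on this read-out, with the S form giving the stronger inhibition of this pair, something the earlier compounds could not show: no measured pair before this one differed in configuration alone. With no atom or bond changed, the shift can be assigned to this stereocentre and to nothing else in the structure, due to one plain point: the fact that compounds 2 and 3 differ only in the configuration as drawn

Within the data shown here, this is only one pair, so it remains open whether S would also give the lower number with other groups elsewhere on the shared core, and the data do not explain how the inverted carbon produces the shift. Also open, as far as these compounds go, is what a carboxylic acid or a methyl group on that same ring carbon would do to the number, in either configuration.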